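The source may report more compounds than this note shows. Statements on the series, on what has been measured and on what is new or still open speak of the compounds shown alone.

Of the compounds shown here, two built on the same core have been measured. Compound 1 `Cc1cc(C)n2nc(NCCN(C)C)c(S(=O)(=O)c3ccccc3)c2n1` carries a (2-(dimethylamino)ethyl)amino group on an aromatic carbon, and in a functional assay on HEK293 cells for antagonist activity at 5-hydroxytryptamine receptor 6 (Homo sapiens), read by cAMP accumulation, with a stated time of 2 h (a lower number here means a stronger inhibitor, a higher number a weaker inhibitor), compound 1 gives 2600 nM. Compound 2 `Cc1cc(C)n2nc(N(C)C)c(S(=O)(=O)c3ccccc3)c2n1` carries a dimethylamino group in its place, and in this assay compound 2 gives 14.5 nM, the lower of the two numbers: the change is a 180-fold lower number from compound 1 to compound 2 (2.25 log units; beyond the scatter).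

Compound 3 `Cc1cc(C)n2nc(N(C)CCN(C)C)c(S(=O)(=O)c3ccccc3)c2n1` has not yet been measured. It differs from compound 2 by (dimethylamino)methyl in place of hydrogen on a saturated chain carbon bound to a nitrogen on an aromatic ring, so that compound 3 holds both the methyl of compound 2 and the 2-(dimethylamino)ethyl chain of compound 1 on the same nitrogen.

Within the data shown here, the only measured step that bears on this is the one from compound 1 to compound 2, which shows that the 2-(dimethylamino)ethyl chain goes with a much higher number than a methyl. Compound 3 keeps a methyl, so the full size of that step need not return, but a clear rise beyond the scatter is expected. For compound 3 the estimate in this assay is 300 nM, with a likely range from 60 nM to 1500 nM, which is expected to mean a step of a 21-fold higher number from compound 2 to compound 3 (1.32 log units; beyond the scatter).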

Compound 3, inhibition constant: 489 nM
Compound 3: middle estimate off by 1.6-fold (0.21 log units), on the low side; the range from low to high includes it.
By their numbers in this assay, from the lowest: compound 2; then compound 3; then compound 1.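

Among these compounds, compound 3 pulls apart two changes that were bundled in the single step of a 180-fold lower number from compound 1 to compound 2 (2.25 log units; beyond the scatter), since that step both removed the 2-(dimethylamino)ethyl chain and put a methyl on the nitrogen. In this assay, with the methyl held in place, replacing it with the longer chain gives a 34-fold higher number from compound 2 to compound 3 (1.53 log units; beyond the scatter), so the chain alone carries a large penalty. With the chain held in place, methyl in place of hydrogen on the nitrogen gives a 5.3-fold lower number from compound 1 to compound 3 (0.73 log units; beyond the scatter), a modest step but one still beyond the scatter, so the larger share of the original drop goes with the chain and a smaller but real share goes with the methyl.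

These compounds cannot separate the length of the chain from the dimethylamino group at its end, and a 2-methoxyethyl or a plain propyl group on the same nitrogen would address that question. No measurement on hand explains why either change moves the number, so the reason for these steps stays open.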